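Dropping One Methoxy Group: Expected Effect on Cytotoxicity

The compounds below may be only part of what the source reports. "The series", "measured", "known", "first", "only" and "open" are said of these compounds alone.

The study measured a functional assay on HPLF cells (Homo sapiens) for cytotoxicity; a lower number here means that less compound is tolerated, a higher number that more compound is tolerated. Compound 1, `COc1cc(/C=C2\CCC/C(=C\c3ccc([N+](=O)[O-])cc3)C2=O)ccc1O`, gives 171000 nM in this assay. Compound 2, `COc1cc(/C=C2\Cc3ccccc3/C(=C\c3ccc([N+](=O)[O-])cc3)C2=O)cc(OC)c1OC`, stands apart: in this assay compound 2 reaches only the limit of > 400000 nM, so no number is known for it. Its standing is described by the limit of > 400000 nM in this assay, at which 1 of the 2 values shown sits. Compound 3, `COc1ccc(/C=C2\Cc3ccccc3/C(=C\c3ccc([N+](=O)[O-])cc3)C2=O)cc1OC`, has not yet been measured; it differs from compound 2 by hydrogen in place of methoxy on an aromatic carbon. For the measured compounds named here, no measured pair shows what such a change does here. Compound 1 and compound 2 differ in more than one place, so their two values show only that one sits at a number and the other at the limit. The change is expected to shift the value little, if at all: an at least 1.3-fold lower number from compound 2 to compound 3 (0.12 log units; that floor lies within the scatter). Compound 3 is therefore estimated at 300000 nM, with a range from 100000 nM to 800000 nM.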

Compound 3, half-maximal cytotoxic concentration: > 400000 nM
Compound 3 was reported as a limit (the forecaster's own chance of this, stated with the estimate: 50%); at least 1.3-fold (0.12 log units) between middle value and limit.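

No step can be read between compound 2 and compound 3, since both stand at a limit and not at a number in this assay. The compounds shown leave open what hydrogen in place of methoxy on an aromatic carbon does to the value.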